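Swapping the Core Substituent Far from the Amine

This account rests on a few compounds, and the source may have more. Where it says the series, first, only, none or still open, it means among the compounds named here.

Compound 1, `COc1ccc(F)cc1CNCCCNc1ccnc2cc(Cc3cc(C)cc(C)c3)ccc12`, compound 2, `COc1cccc(CNCCCNc2ccnc3cc(Cc4ccccc4)ccc23)c1O`, and compound 3, `COc1ccc(F)cc1CNCCCNc1ccnc2cc(Cc3ccccc3)ccc12`, share one core and one secondary amine chain. In a physicochemical assay for acid dissociation, compound 1 gives 9.47, compound 2 gives 9.47 and compound 3 gives 9.47. Compound 2 stands level with the other two at the digits shown. The step of no change at the digits printed from compound 1 to compound 3 (within the scatter) and the step of no change at the digits printed from compound 2 to compound 3 (within the scatter) both leave the value where it was, whether the group on a saturated chain carbon bound to an aromatic carbon or the group on a saturated chain carbon bound to an amine nitrogen is exchanged.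

The untested compound 4, `COc1cccc(CNCCCNc2ccnc3cc(Oc4ccc(C(C)(C)C)cc4)ccc23)c1O`, differs from compound 2 by 4-(tert-butyl)phenoxy in place of benzyl on an aromatic carbon. The measured step that bears most directly on this is no change at the digits printed from compound 1 to compound 3 (within the scatter), which exchanged the group on an aromatic carbon of the core with no movement; the step of no change at the digits printed from compound 2 to compound 3 (within the scatter) shows the same picture. For compound 4 the expected step of no change at the digits printed from compound 2 to compound 4 (within the scatter) is therefore none beyond the scatter. Compound 4 is estimated at 9.47, within 9.1 to 9.8.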

Compound 4, acid dissociation constant: 9.28
The estimate for compound 4 lay 0.19 log units above the measured number; the measured number falls inside the stated range.
By their numbers in this assay, from the lowest: compounds 4, 1, 2 and 3 (each within the scatter of the next).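

The step at this position is larger in kind than the earlier one: compound 1 to compound 3 only altered the outer ring of a benzyl-type group, whereas here benzyl, with 7 heavy atoms, gives way to 4-(tert-butyl)phenoxy, with 11 heavy atoms including an oxygen and one hydrogen-bond acceptor. Even so, this assay records a number 0.19 log units lower from compound 2 to compound 4 (within the scatter), so this position on the core tolerates a new linking atom together with a larger group without a reading beyond the scatter. No supporting measurement is available to explain the size of this step.

The compounds shown do not separate the oxygen link from the tert-butyl group, which a plain phenoxy group would address. They also leave open whether an amine or a carboxylic acid at this position would stay within the scatter in this assay.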